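This account rests on a few compounds, and the source may have more. Where it says the series, first, only, none or still open, it means among the compounds named here.

Measured so far in a functional assay on HCT-116 cells (Homo sapiens), read by MTT assay, with a stated time of 72 h; on this read-out higher numbers stand for weaker inhibition and lower numbers for stronger inhibition:

Compound 3, `Nc1nc2c(c(-c3ccoc3)cn2[C@@H]2O[C@H](CO)[C@@H](O)[C@H]2O)c(=O)[nH]1`, gives 14200 nM.
Compound 1, `Nc1nc2c(c(-c3ccco3)cn2[C@@H]2O[C@H](CO)[C@@H](O)[C@H]2O)c(=O)[nH]1`, gives > 20000 nM, which is a limit of the assay and not a number.
Compound 2, `COc1nc(N)nc2c1c(-c1ccoc1)cn2[C@@H]1O[C@H](CO)[C@@H](O)[C@H]1O`, gives > 20000 nM, which is again a limit of the assay and not a number.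

Compound 1 and compound 3 share a core and differ by one change, (furan-2-yl in place of furan-3-yl on an aromatic carbon). That change gave an at least 1.4-fold higher number from compound 3 to compound 1 (0.14 log units; that floor lies within the scatter), so within these measurements it did not make the inhibition stronger. Compound 2 carries a different core; how the core of compound 2 differs from that of compound 3 is not broken down here. Compound 4, `COc1nc(N)nc2c1c(-c1ccco1)cn2[C@@H]1O[C@H](CO)[C@@H](O)[C@H]1O`, has not yet been measured in this assay. It stands to compound 2 as compound 1 stands to compound 3, by the same change, (furan-2-yl in place of furan-3-yl on an aromatic carbon), at the same place. Compound 2 already sits at the limit of > 20000 nM in this assay, at which 2 of the 3 values shown sit. Among the measured compounds shown here, since the one measured example of this change, from compound 3 to compound 1, moved the number upward, and since compound 2 gives only a limit, a similar outcome for compound 4 is expected, namely a step that the limit leaves unreadable from compound 2 to compound 4. Compound 4 is therefore expected to give about 35000 nM, most likely reported only as a limit. The expected range for compound 4 runs from 15000 nM to 100000 nM.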

Compound 4, half-maximal inhibitory concentration: > 20000 nM
Compound 4: only a limit was reported (the forecaster's own chance of this, stated with the estimate: 85%); the middle value does not contradict the limit.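

In this assay compound 4 gives only a limit, and so does compound 2, so no step can be read between the two for furan-2-yl in place of furan-3-yl: the limit of > 20000 nM in this assay, at which 3 of the 4 values shown sit. The compounds shown leave open whether this change alters the inhibition at all on the core of compound 2, and how compound 2 and compound 4 truly compare.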